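The source may hold more compounds than are shown below. What is called first, only, known or untested is meant among the compounds shown, and "the series" means these compounds.

Within the data shown here, compound 1 `Oc1ccc(-c2cc(-c3ccco3)nc(-c3ccccc3Cl)c2)cc1` gives 4310 nM in an ADME assay on HEK293 cells (Homo sapiens) for cytotoxicity, read by CCK-8 assay and cell counting, with a stated time of 2 days (a lower number here means a stronger inhibitor, a higher number a weaker inhibitor), the lower of the two numbers so far. Compound 2 `Oc1ccc(-c2cc(-c3ccsc3)nc(-c3ccccc3Cl)c2)cc1` gives 5930 nM in this assay; the step of a 1.4-fold higher number from compound 1 to compound 2 (0.14 log units; within the scatter) is within the scatter. Compound 3 `Oc1cccc(-c2cc(-c3ccco3)nc(-c3ccccc3Cl)c2)c1` differs from compound 1 by 3-hydroxyphenyl in place of 4-hydroxyphenyl on an aromatic carbon. Among the measured compounds shown here, no measured step touches this position; the one step known changes a different group and stays within the scatter, so for compound 3 the step of a 1.2-fold higher number from compound 1 to compound 3 (0.06 log units; within the scatter) in this assay is expected to show no change beyond the scatter. Compound 3 is estimated at 5000 nM, in the range 2000 nM to 13000 nM.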

Compound 3, half-maximal inhibitory concentration: 1860 nM
The estimate for compound 3 lay 2.7-fold (0.43 log units) above the measured number; the whole stated range lies above it.
By their numbers in this assay, from the lowest: compound 3; then compounds 1 and 2 (each within the scatter of the next).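

In this assay, the group opposite the ring nitrogen responds to a change that keeps its atoms and counts the same: 3-hydroxyphenyl in place of 4-hydroxyphenyl gives a 2.3-fold lower number from compound 1 to compound 3 (0.36 log units; beyond the scatter). Among these compounds, this is the first step to pass beyond the scatter, unlike a 1.4-fold higher number from compound 1 to compound 2 (0.14 log units; within the scatter), which changes a different group. No measurement at hand accounts for this step.

On these data alone, it remains open whether a methoxy group in place of the hydroxyl, or an amine at this position, would shift the number further. Also open, as far as these compounds go, is whether the step carries over when thiophen-3-yl replaces furan-2-yl.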